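Ester side chain variants on the shared core: compound 4

The source may report more compounds than this note shows. Statements on the series, on what has been measured and on what is new or still open speak of the compounds shown alone.

Measured so far in a functional assay on HeLa cells (Homo sapiens) for cytotoxicity, read by MTT assay; a higher number here means a weaker inhibitor, a lower number a stronger inhibitor:
compound 1 `CC(C)=CC[C@@H](OC(=O)CC(C)(O)c1ccccc1)C1=CC(=O)c2c(O)ccc(O)c2C1=O` gives 85700 nM
compound 2 `CC[C@](C)(O)CC(=O)O[C@H](CC=C(C)C)C1=CC(=O)c2c(O)ccc(O)c2C1=O` gives 30200 nM
compound 3 `CC(C)=CC[C@@H](OC(=O)CC(C)(O)C(C)C)C1=CC(=O)c2c(O)ccc(O)c2C1=O` gives 27700 nM

Compound 3 holds the lowest of the three numbers in this assay, but its gap to compound 2 is within the scatter (a 1.1-fold lower number from compound 2 to compound 3 (0.04 log units; within the scatter)), so the two cannot be ordered; only compound 1 stands apart (a 3.1-fold lower number from compound 1 to compound 3 (0.49 log units; beyond the scatter)).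

Compound 4 `CC(C)=CC[C@@H](OC(=O)CC(O)c1ccccc1)C1=CC(=O)c2c(O)ccc(O)c2C1=O` differs from compound 3 as follows: hydroxy(phenyl)methyl in place of 1-hydroxy-1,2-dimethylpropyl on a saturated chain carbon bound to a carbonyl carbon. Among the measured compounds shown here, two measured steps bear on it. Going from compound 1 to compound 2 and from compound 1 to compound 3, an alkyl took the place of a phenyl on the side chain, and both moved the number down modestly (a 2.8-fold lower number from compound 1 to compound 2 (0.45 log units; beyond the scatter), a 3.1-fold lower number from compound 1 to compound 3 (0.49 log units; beyond the scatter)). For the measured compounds named here, compound 4 brings a phenyl back, though with the methyl also removed, for which there is no measured step. The expectation is therefore a step in the opposite direction, toward the number of compound 1, of modest size: a 2.2-fold higher number from compound 3 to compound 4 (0.34 log units; beyond the scatter).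

For compound 4 the estimate in this assay is 60000 nM, with a range of 25000 nM to 150000 nM.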

Compound 4, half-maximal inhibitory concentration: 44500 nM
Estimate against measurement, compound 4: 1.3-fold (0.13 log units) above; low and high end bracket the measured number.
By their numbers in this assay, from the lowest: compounds 3, 2, 4 and 1 (each within the scatter of the next, the first and the last beyond it).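

In this assay, hydrogen in place of methyl on the phenyl-bearing side chain gives a 1.9-fold lower number from compound 1 to compound 4 (0.28 log units; within the scatter) and so leaves this change unresolved. Hydroxy(phenyl)methyl also cannot be told apart from either alkyl side chain, with a 1.6-fold higher number from compound 3 to compound 4 (0.21 log units; within the scatter) against 1-hydroxy-1,2-dimethylpropyl and a 1.5-fold higher number from compound 2 to compound 4 (0.17 log units; within the scatter) against 1-hydroxy-1-methylpropyl, so the gap that compound 1 holds to compound 2 and compound 3 does not appear for the phenyl side chain of compound 4. Nothing at hand gives a reason for any of these differences.

The effect of hydrogen in place of methyl on an alkyl side chain remains open, as the compounds shown test this change only alongside a phenyl. Also open, as far as these compounds go, is whether an amine in place of the hydroxy, or a longer chain in place of the phenyl, would give a step beyond the scatter.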